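The source may hold more compounds than are shown below. What is called first, only, known or untested is meant among the compounds shown, and "the series" means these compounds.

Measured so far:
- compound 1 `O=C(NCCCNc1cc(-c2cn(-c3ccccc3)nc2-c2cccc(O)c2)ccn1)Nc1ccc(F)cc1` gives 8690 nM
- compound 2 `O=C(NCCCNc1cc(-c2cn(-c3ccccc3)nc2-c2cccc(O)c2)ccn1)Nc1cccc(C(F)(F)F)c1` gives 9350 nM

Among the measured compounds shown here, in a functional assay on OVCAR-3 cells (Homo sapiens) for antiproliferative activity, read by sulforhodamine B assay, with a stated time of 48 h (a lower number here means a stronger inhibitor of growth, a higher number a weaker inhibitor of growth), compound 1 stands level with compound 2, the only other compound measured, and the single step is a 1.1-fold higher number from compound 1 to compound 2 (0.03 log units; within the scatter) at a different place in the structure. Compound 3 `COc1cccc(-c2nn(-c3ccccc3)cc2-c2ccnc(NCCCNC(=O)Nc3ccc(F)cc3)c2)c1` differs from compound 1 by methyl in place of hydrogen on an oxygen on an aromatic ring and thus has 3-methoxyphenyl in place of 3-hydroxyphenyl. For the measured compounds named here, no measured step covers this change, so nothing beyond the scatter is firmly expected in either direction, and the margin stays wide. The expected step is a 1.2-fold higher number from compound 1 to compound 3 (0.06 log units; within the scatter) on this estimate. The estimate for compound 3 is 10000 nM with 4000 nM to 25000 nM as its range.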

Compound 3, concentration for total growth inhibition: > 37000 nM
Compound 3: only a limit was reported; the forecaster's own chance of this, stated with the estimate: 10%; at least 3.7-fold (0.56 log units) between middle value and limit.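

In this assay, the change from 3-hydroxyphenyl to 3-methoxyphenyl gives an at least 4.2-fold higher number from compound 1 to compound 3 (0.62 log units; beyond the scatter), so growth inhibition responds to this oxygen substituent, whereas the earlier change on the amide-type nitrogen stayed within the scatter. The figure for compound 3 is a limit and not a number, so the full size of this step stays unknown: the limit of > 37000 nM in this assay, at which 1 of the 3 values shown sits.

The compounds shown do not tell whether the weakening comes from losing the hydrogen or from adding the methyl. Going by these compounds, an amino group, a fluorine or an ethoxy group at this place would help separate the two, and the same change alongside the 3-(trifluoromethyl)phenyl urea of compound 2 remains open.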